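Swapping an Imidazole for a Pyridinyl Ether

The source may hold more compounds than are shown below. What is called first, only, known or untested is meant among the compounds shown, and "the series" means these compounds.

Of the compounds shown here, two built on one shared core have been measured in a functional assay for inhibition of sodium/hydrogen exchanger (Oryctolagus cuniculus); on this read-out lower numbers stand for stronger inhibition and higher numbers for weaker inhibition. Compound 2 `CS(=O)(=O)c1cc(C(=O)N=C(N)N)ccc1-n1ccnc1` gives 150 nM in this assay, the lowest of the two numbers. Compound 1 `Cc1c(C(=O)N=C(N)N)ccc(Oc2cccnc2)c1S(C)(=O)=O`, which carries a (pyridin-3-yl)oxy group and an additional methyl group, gives 2200 nM in this assay, a number beyond the scatter above that of compound 2. Compound 3 `CS(=O)(=O)c1cc(C(=O)N=C(N)N)ccc1Oc1cccnc1` has not yet been measured. It differs from compound 2 in one place: (pyridin-3-yl)oxy in place of 1H-imidazol-1-yl on an aromatic carbon. Among the measured compounds shown here, no step between two measured compounds isolates exactly this change, so the expectation rests on compound 1. Compound 3 is expected to lose potency in this assay by roughly a 10-fold higher number from compound 2 to compound 3 (1.00 log units; beyond the scatter), a step beyond the scatter, because compound 1 with the same (pyridin-3-yl)oxy group gives 2200 nM. Compound 3 is therefore estimated at 1500 nM, with a range from 400 nM to 5000 nM.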

Compound 3, half-maximal inhibitory concentration: 76 nM
Beside the measured number, compound 3's estimate is 20-fold (1.30 log units) above it, and the stated range ends above it.
By their numbers in this assay, from the lowest: compounds 3 and 2 (each within the scatter of the next); then compound 1.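

Placing (pyridin-3-yl)oxy in place of 1H-imidazol-1-yl on this aromatic carbon, ortho to a methylsulfonyl group, gives a 2.0-fold lower number from compound 2 to compound 3 (0.30 log units; within the scatter) in this assay and so leaves the read-out unchanged within the usual scatter. The high number of compound 1 therefore does not go with the (pyridin-3-yl)oxy group on its own: hydrogen in place of methyl on an aromatic carbon gives a 29-fold lower number from compound 1 to compound 3 (1.46 log units; beyond the scatter) and marks that single methyl group as the change that matters in this pair. No measurement offered here explains why either step has the size it does.

As far as these compounds go, whether a plain phenoxy group or an amine at the same position would stay in this range remains open. So does whether an ethyl group or a chlorine atom in place of that methyl group would bring a similarly large step.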